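Oral bioavailability notes: replacing the group on the aromatic nitrogen

The source may hold more compounds than are shown below. What is called first, only, known or untested is meant among the compounds shown, and "the series" means these compounds.

compound 1 `N#Cc1c(-c2ccc3c(ccn3[C@H]3CC[C@H](O)CC3)c2)ccn2c(CC(F)(F)F)cnc12`: 50%
compound 2 `O[C@H]1CC[C@H](n2ccc3cc(-c4ccn5c(CC(F)(F)F)cnc5c4Cl)ccc32)CC1`: 100%
compound 3 `N#Cc1c(-c2ccc(Oc3ccccc3)cc2)ccn2c(CC(F)(F)F)cnc12`: 27%

In an in vivo ADME assay on the whole organism (strain Sprague-Dawley) for pharmacokinetics, with Rattus norvegicus as the target, at a dose of 10 mg/kg by the oral route (on this read-out lower numbers stand for lower oral bioavailability and higher numbers for higher oral bioavailability), compound 1 gives 50%, the second highest of the three numbers. Compound 3 lies lower and compound 2 higher, both gaps beyond the scatter.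

The step followed here leads to compound 4 `N#Cc1c(-c2ccc3c(ccn3C3CCOCC3)c2)ccn2c(CC(F)(F)F)cnc12`, which has not yet been measured. The change is oxan-4-yl in place of 4-hydroxycyclohexyl on an aromatic nitrogen.

Within the data shown here, the only measured step is a number 50 percentage points higher from compound 1 to compound 2 (beyond the scatter). It is large and beyond the scatter, but it is a different change, chloro in place of cyano on an aromatic carbon, and leaves the group on the aromatic nitrogen untouched. Among the measured compounds shown here, no measured pair varies that group, so the data give neither a size nor a direction for this change. The expectation therefore stays anchored on compound 1 at 50%, and no step beyond the scatter is expected in this assay.

The estimate amounts to an expected a number 5 percentage points higher from compound 1 to compound 4 (within the scatter). For compound 4 the expected value is 55%, with an estimated range of 30% to 80%.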

Compound 4, oral bioavailability: 15%
Beside the measured number, compound 4's estimate is 40 percentage points above it; the whole stated range lies above it.
By their numbers in this assay, from the lowest: compound 4; then compound 3; then compound 1; then compound 2.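

Among these compounds, the group on the aromatic nitrogen is not a silent position in this assay: a number 35 percentage points lower from compound 1 to compound 4 (beyond the scatter) and this is the first step to vary that group, with oxan-4-yl in place of 4-hydroxycyclohexyl. The exchange removes the hydrogen-bond donor, keeps one hydrogen-bond acceptor, takes away one heavy atom and leaves no defined stereocentres, but this single pair cannot separate these differences from one another as the source of the step. No measurement at hand bears on what lies behind it.

Going by these compounds, it remains open whether the same exchange would give a step of similar size and direction on the chloro counterpart, compound 2, whose cyano-to-chloro change was read only with 4-hydroxycyclohexyl on the aromatic nitrogen. Also open, on these data alone, is how plain cyclohexyl, a 4-aminocyclohexyl group or a 4-carboxycyclohexyl group would stand on that nitrogen, and these would show whether the hydroxyl itself or the ring carrying it tracks with the oral bioavailability seen here.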